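The compounds below may be only part of what the source reports. "The series", "measured", "known", "first", "only" and "open" are said of these compounds alone.

Measured compounds:
- compound 1 `O=C(OCCc1c(-c2ccccc2Cl)c2cc(Cl)ccc2[nH]c1=O)c1ccccc1`: 43000 nM
- compound 2 `O=C(OCCc1c(-c2ccccc2Cl)c2cc(Cl)ccc2[nH]c1=O)c1ccco1`: 98000 nM
- compound 3 `COc1ccccc1/C=C/C(=O)OCCc1c(-c2ccccc2Cl)c2cc(Cl)ccc2[nH]c1=O`: 770000 nM

In an ADME assay on HepG2 2.2.15 cells (Homo sapiens) for cytotoxicity (a lower number here means that less compound is tolerated, a higher number that more compound is tolerated), compound 3 gives the highest number of the three, with compound 2 nearest and compound 1 furthest, both steps beyond the scatter. Compound 4 `C/C=C(\C)C(=O)OCCc1c(-c2ccccc2Cl)c2cc(Cl)ccc2[nH]c1=O` differs from compound 3 in one place: 1-methylprop-1-en-1-yl in place of 2-(2-methoxyphenyl)ethenyl on a carbonyl carbon.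

The change sits on the same carbonyl carbon that was varied in the measured steps. Exchanging the group on that carbon moved this assay by an 18-fold higher number from compound 1 to compound 3 (1.25 log units; beyond the scatter) and by a 7.9-fold higher number from compound 2 to compound 3 (0.90 log units; beyond the scatter), and between the two smaller groups by a 2.3-fold higher number from compound 1 to compound 2 (0.36 log units; beyond the scatter). Going by the values given here, the group entering compound 4 has no ring and fewer heavy atoms than any of the three measured groups, so no measured step matches it closely. Since the ring-bearing groups of compound 1 and compound 2 gave lower numbers than compound 3, a drop from compound 3 to compound 4 is expected, of a modest size, a 5.1-fold lower number from compound 3 to compound 4 (0.71 log units; beyond the scatter), with wide uncertainty. For compound 4 the estimate in this assay is 150000 nM, ranging from 40000 nM to 600000 nM.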

Compound 4, half-maximal cytotoxic concentration: 350000 nM
Estimate against measurement, compound 4: 2.3-fold (0.37 log units) below, and the stated range covers the measured number.
By their numbers in this assay, from the lowest: compound 1; then compound 2; then compound 4; then compound 3.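

In this assay, the ring-free 1-methylprop-1-en-1-yl on the carbonyl carbon gives a higher number than either ring group directly on that carbon, with an 8.1-fold higher number from compound 1 to compound 4 (0.91 log units; beyond the scatter) and a 3.6-fold higher number from compound 2 to compound 4 (0.55 log units; beyond the scatter), so a ring there is not required for a high number. Against 2-(2-methoxyphenyl)ethenyl the step is a 2.2-fold lower number from compound 3 to compound 4 (0.34 log units; beyond the scatter), so the two groups with a double bond outside aromatic rings give the two highest numbers of the four, and heavy-atom count does not order the series, since compound 4, with the fewest, ranks second. No evidence at hand accounts for these steps.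

The compounds shown leave open whether the double bond matters, which a saturated chain such as butan-2-yl on the same carbonyl carbon could separate from chain shape. Also open, going by these compounds, is whether this order survives an amide nitrogen in place of the oxygen on that carbonyl carbon.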